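The source may hold more compounds than are shown below. What is called first, only, known or untested is meant among the compounds shown, and "the series" means these compounds.

Values in a physicochemical assay for solubility, in phosphate buffer, at pH 7.4 (a lower number here means a less soluble compound, a higher number a more soluble compound), so far
Compound 1 `CC(=O)N[C@@H]1CCC[C@H](C(=O)Nc2cc(-c3cnc(C)n3C(C)C)ccn2)C1` gives 660000 nM
Compound 2 `CC(=O)N[C@@H]1CCC[C@H](C(=O)Nc2cc(-c3cnn4c3CCC4)c(Cl)cn2)C1` gives 160000 nM
Compound 3 `CC(=O)N[C@@H]1CCC[C@H](C(=O)Nc2cc(-c3cnn4c3CC(C)(C)C4)c(C#N)cn2)C1` gives 380000 nM

Compound 2 stands lowest of the three. Compound 3 and compound 1 both give higher numbers, each beyond the scatter. Going by the values given here, no two measured compounds differ in one place only, so no measured step is available as a guide.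

Compound 4 `CC(=O)N[C@@H]1CCC[C@H](C(=O)Nc2cc(-c3cnc4n3CC(C)(C)C4)c(Cl)cn2)C1` has not yet been measured. Relative to compound 2 it carries one change, (a group of 10 heavy atoms (8 carbon, 2 nitrogen; one five-membered non-aromatic ring with 1 hetero atom, one five-membered aromatic ring with 2 hetero atoms) in place of a group of 8 heavy atoms (6 carbon, 2 nitrogen; one five-membered non-aromatic ring with 1 hetero atom, one five-membered aromatic ring with 2 hetero atoms), on an aromatic carbon), ortho to a chloro group and opposite the ring nitrogen.

With compound 2 at 160000 nM as the starting point and compound 1 at 660000 nM as the highest number seen, no change beyond the scatter is expected, with only a slight lean upward. The expected step is a 1.3-fold higher number from compound 2 to compound 4 (0.10 log units; within the scatter) and it is estimated to stay within the scatter. The estimate for compound 4 is 200000 nM with an expected range of 80000 nM to 500000 nM in this assay when the measurement is made.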

Compound 4, solubility: 280000 nM
For compound 4 the middle estimate is 1.4-fold (0.15 log units) below the measured one; the measured number falls inside the stated range.
By their numbers in this assay, from the lowest: compounds 2, 4, 3 and 1 (each within the scatter of the next, the first and the last beyond it).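

In this assay, going by these compounds alone, the pair gives the first reading of a single change, a 1.8-fold higher number from compound 2 to compound 4 (0.24 log units; within the scatter), for the group of 10 heavy atoms in place of the group of 8 heavy atoms, on an aromatic carbon ortho to a chloro group and opposite the ring nitrogen. With the chloro group and the rest of the molecule held constant, this exchange is not resolved from the scatter, and it remains a single pair at a single position. No independent measurement bears on the size of this step.

From the compounds shown here alone, whether the same exchange gives a similar step with a nitrile in place of the chloro group remains open. Also open, going by these compounds, is how this assay responds at this position to a group carrying an amine or a carboxylic acid.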